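The source may hold more compounds than are shown below. What is called first, only, known or untested is meant among the compounds shown, and "the series" means these compounds.

Working notes on the piperazine series and its thiophene core.

Compound 1 `CC(C)N1CCN(Cc2csc(N)c2C(=O)c2ccc(Cl)cc2)CC1` is the reference point. In an assay on CHO cells for displacement of a labelled ligand from adenosine receptor A3 (Homo sapiens), read by scintillation counting, with a stated time of 120 min, tested at 10 uM (a lower number here means less inhibition, a higher number more inhibition at the concentration tested (going by the name of the read-out)), compound 1 gives 0%. The two ring-nitrogen variants measured so far sit at the same place: compound 2 `Nc1scc(CN2CCN(c3cccc(Cl)c3Cl)CC2)c1C(=O)c1ccc(Cl)cc1` gives 0%, and compound 3 `Nc1scc(CN2CCN(c3ccc(F)cc3Cl)CC2)c1C(=O)c1ccc(Cl)cc1` gives 0%. The step of no change at the digits printed from compound 1 to compound 2 (within the scatter) and the step of no change at the digits printed from compound 1 to compound 3 (within the scatter) both stay within the scatter, as does the step of no change at the digits printed from compound 2 to compound 3 (within the scatter) between the two aryl groups. Compound 1 is therefore level with compounds 2 and 3 at the digits reported, with nothing in the set standing apart.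

Compound 4 `Nc1scc(CN2CCN(c3cccc(F)c3)CC2)c1C(=O)c1ccc(Cl)cc1` has not yet been measured. It differs from compound 1 in one place: 3-fluorophenyl in place of isopropyl on an amine nitrogen in a ring. Among the measured compounds shown here, the steps that bear on it are those from compound 1 to compounds 2 and 3, each an aryl group entering on the same ring nitrogen, and each without change beyond the scatter. The expected step is accordingly no change at the digits printed from compound 1 to compound 4 (within the scatter), with no direction beyond the scatter. Compound 4 is estimated at 0%, in a range from 0% to 10%.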

Compound 4, a percentage reported as inhibition, at one concentration (the size of the read-out at that concentration, not a potency): 4%
Estimate against measurement, compound 4: 4 percentage points below, and the stated range covers the measured number.
By their numbers in this assay, from the lowest: compounds 1, 2, 3 and 4 (each within the scatter of the next).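

In this assay, 3-fluorophenyl, an aryl group without chlorine, also stays within the scatter of isopropyl on this amine nitrogen in a ring (a number 4 percentage points higher from compound 1 to compound 4 (within the scatter)). The chlorine-bearing aryl groups give the same reading (a number 4 percentage points higher from compound 3 to compound 4 (within the scatter); a number 4 percentage points higher from compound 2 to compound 4 (within the scatter)), so neither aryl group in place of isopropyl nor the exchange among these three aryl groups separates any of the four compounds. No supporting data bear on this result.

The compounds shown carry only isopropyl and halogen-substituted phenyl groups on this nitrogen, so whether a carboxylic acid, an acyl group or a longer alkyl chain there would give a reading beyond the scatter remains open. As far as these compounds go, the 4-chlorophenyl ketone and the free amine on the shared core are constant throughout, so changes at either also remain open.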